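Bromo on the aromatic ring of compound 1

This account rests on a few compounds, and the source may have more. Where it says the series, first, only, none or still open, it means among the compounds named here.

Compound 1 (`Cn1c([N+](=O)[O-])cnc1/C=C/c1ccccc1`) gives > 100000 nM in an ADME assay on HeLa cells (Homo sapiens) for cytotoxicity, read by resazurin assay, with a stated time of 2 days (a higher number here means a weaker inhibitor, a lower number a stronger inhibitor), as a limit of the assay and not a number. Only one entry of the series is of this kind (the limit of > 100000 nM in this assay, at which 1 of the 3 values shown sits). The step to compound 4 (`Cn1c([N+](=O)[O-])cnc1/C=C/c1ccc(Br)cc1`) is a single change (bromo in place of hydrogen on an aromatic carbon).

Going by the values given here, two measured steps bear on it. Compound 3 (`Cn1c([N+](=O)[O-])cnc1/C=C/c1ccccc1Br`) also carries bromo in place of hydrogen on an aromatic carbon, at another place, and gives 72400 nM in this assay. The step that leads there (an at least 1.3-fold lower number from compound 1 to compound 3 (0.14 log units; that floor lies within the scatter)) is not shown to lie beyond the scatter. Compound 2 (`Cc1cccc(/C=C/c2ncc([N+](=O)[O-])n2C)c1`) carries methyl in place of hydrogen on an aromatic carbon and gives 30900 nM with a step (an at least 3.2-fold lower number from compound 1 to compound 2 (0.51 log units; beyond the scatter)) beyond the scatter.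

Compound 3 at 72400 nM is the closer match, so a lower number of modest size is expected. The expected step (an at least 1.6-fold lower number from compound 1 to compound 4 (0.22 log units; that floor lies within the scatter)) starts from a limit, so its size remains an estimate. Compound 4 is estimated at 60000 nM (expected range 25000 nM to 100000 nM).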

Compound 4, half-maximal inhibitory concentration: 72400 nM
Compound 4: the middle estimate sits 1.2-fold (0.08 log units) below what was measured; the measured number falls inside the stated range.
By their numbers in this assay, from the lowest: compound 2; then compounds 3 and 4 (each within the scatter of the next). At a limit, above all of these: compound 1.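

With bromo on an aromatic carbon para to a large group, the step is an at least 1.3-fold lower number from compound 1 to compound 4 (0.14 log units; that floor lies within the scatter), so this position, like the bromo place in compound 3, shows no step beyond the scatter. In this assay compound 3 gives 72400 nM and compound 4 gives 72400 nM, so moving the bromo between these two places leaves the number unchanged. Compound 1 gives > 100000 nM, which is a limit and not a number, so the step has only a floor: the limit of > 100000 nM in this assay, at which 1 of the 4 values shown sits.

Still open, on these data alone, is how an amine or a carboxylic acid on this same aromatic carbon would read in this assay. Also open, as far as these compounds go, is whether methyl at this position would give a step like an at least 3.2-fold lower number from compound 1 to compound 2 (0.51 log units; beyond the scatter), which lies beyond the scatter.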